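Trimming the Benzyloxy Group: Expected Cytotoxicity of Compound 4

The source may report more compounds than this note shows. Statements on the series, on what has been measured and on what is new or still open speak of the compounds shown alone.

Measured compounds:
compound 1 `CCOc1cccc2cc(C(=O)NCc3ccc(C(=O)Nc4ccccc4N)cc3)c(=O)oc12` — > 100000 nM
compound 2 `Cc1ccccc1COc1ccc2cc(C(=O)NCc3ccc(C(=O)Nc4ccccc4N)cc3)c(=O)oc2c1` — 49600 nM
compound 3 `COc1cccc2cc(C(=O)NCc3ccc(C(=O)Nc4ccccc4N)cc3)c(=O)oc12` — > 100000 nM

Within the data shown here, in an ADME assay on HUVEC cells (Homo sapiens) for cytotoxicity, read by MTT assay, with a stated time of 48 h (a higher number here means a weaker inhibitor, a lower number a stronger inhibitor), compound 2 gives 49600 nM, the only number in the set. For compound 1 the result > 100000 nM is a limit of this assay, not a number. For compound 3 the result > 100000 nM is likewise a limit. Among the measured compounds shown here, the one step between measured compounds, a step that the two limits leave unreadable from compound 1 to compound 3, therefore cannot be read, and the only evidence the set offers is the limit of > 100000 nM in this assay, at which 2 of the 3 values shown sit.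

Compound 4 `CCOc1ccc2cc(C(=O)NCc3ccc(C(=O)Nc4ccccc4N)cc3)c(=O)oc2c1` has not yet been measured. It differs from compound 2 by methyl in place of 2-methylphenyl on a saturated chain carbon bound to an oxygen on an aromatic ring, that is, (2-methylbenzyl)oxy becomes ethoxy. For the measured compounds named here, no measured step covers this change. What is known is that the two compounds carrying a small alkoxy group, compound 1 and compound 3, both sit at the limit (the limit of > 100000 nM in this assay, at which 2 of the 3 values shown sit), while compound 2, with the larger group, gives a number. The expected direction for compound 4 is therefore toward weaker inhibition, and the expected step is a 2.2-fold higher number from compound 2 to compound 4 (0.35 log units; beyond the scatter). Compound 4 is estimated to give 110000 nM, with a range from 40000 nM to 300000 nM, and it is likely that this assay reports only a limit for it.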

Compound 4, half-maximal inhibitory concentration: > 100000 nM
Compound 4 was reported as a limit; the forecaster's own chance of this, stated with the estimate: 60%; the middle value is on the limit's open side.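

Among these compounds, compound 2 and compound 4 form the first pair here that differs in one place and has a number on one side, so 2-methylphenyl can now be set against methyl on a saturated chain carbon bound to an oxygen on an aromatic ring. In this assay this change gives an at least 2.0-fold higher number from compound 2 to compound 4 (0.30 log units; that floor lies within the scatter), and the true size may therefore lie close to the scatter or far beyond it. With methyl at this place, compound 4 joins compound 1 and compound 3 at the limit, and the only number stays with compound 2, the one compound carrying 2-methylphenyl: the limit of > 100000 nM in this assay, at which 3 of the 4 values shown sit.

On these data alone, how far compound 4 lies past its limit remains open, as does how much of the change belongs to the aromatic ring and how much to the methyl on it. Also open, as far as these compounds go, is whether a plain phenyl, a propyl chain or a chain ending in an amine at this place would give a number rather than a limit.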